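Replacing the chlorophenyl arm with a methoxyphenyl arm

This account rests on a few compounds, and the source may have more. Where it says the series, first, only, none or still open, it means among the compounds named here.

Measured compounds:
- compound 1, `CC(C)(C)c1ccc(CNCCCNS(=O)(=O)c2cc(C(F)(F)F)cc(C(F)(F)F)c2)cc1`, 2700 nM
- compound 2, `O=S(=O)(NCCCNCc1cccc(Cl)c1)c1cc(C(F)(F)F)cc(C(F)(F)F)c1`, 5900 nM
- compound 3, `O=S(=O)(NCCCNCc1ccc(C(F)(F)F)cc1)c1cc(C(F)(F)F)cc(C(F)(F)F)c1`, 2000 nM

All three share a core that carries a sulfonamide and a benzylamine joined by a three-carbon chain. In a functional assay on ASPC1 cells (Homo sapiens) for inhibition, read by MTT assay, with a stated time of 72 h (on this read-out higher numbers stand for weaker inhibition of growth and lower numbers for stronger inhibition of growth), compound 2 gives 5900 nM, the highest number of the three: it differs from compound 1 by a 2.2-fold higher number from compound 1 to compound 2 (0.34 log units; beyond the scatter) and from compound 3 by a 3.0-fold lower number from compound 2 to compound 3 (0.47 log units; beyond the scatter). Compounds 1 and 3 stand within the scatter of each other, a 1.4-fold lower number from compound 1 to compound 3 (0.13 log units; within the scatter).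

Compound 4, `COc1ccc(CNCCCNS(=O)(=O)c2cc(C(F)(F)F)cc(C(F)(F)F)c2)cc1`, has not yet been measured. Its change from compound 2 is 4-methoxyphenyl in place of 3-chlorophenyl on a saturated chain carbon bound to an amine nitrogen. The two measured steps that leave the 3-chlorophenyl of compound 2 both bear on this: the step to compound 1 and the step to compound 3 each moved to a lower number by a modest amount, beyond the scatter. Compound 4 is therefore expected to show a similarly modest step downward in this assay, a 2.4-fold lower number from compound 2 to compound 4 (0.37 log units; beyond the scatter), with the estimate for compound 4 at 2500 nM and a range from 1200 nM to 6000 nM.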

Compound 4, concentration for 50% growth inhibition: 2800 nM
Compound 4: the middle estimate sits 1.1-fold (0.05 log units) below what was measured; measured number inside the range.
By their numbers in this assay, from the lowest: compounds 3, 1 and 4 (each within the scatter of the next); then compound 2.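

In this assay, a third group on a saturated chain carbon bound to an amine nitrogen gives a lower number than the 3-chlorophenyl arm (a 2.1-fold lower number from compound 2 to compound 4 (0.32 log units; beyond the scatter)), and this group carries an oxygen and a hydrogen-bond acceptor. Methoxy stands within the scatter of both trifluoromethyl (a 1.4-fold higher number from compound 3 to compound 4 (0.15 log units; within the scatter)) and tert-butyl (a 1.0-fold higher number from compound 1 to compound 4 (0.02 log units; within the scatter)), so the 4-methoxyphenyl, 4-(trifluoromethyl)phenyl and 4-(tert-butyl)phenyl arms cannot be told apart here. Nothing at hand accounts for the gap between these arms and the 3-chlorophenyl arm.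

Whether the higher number of compound 2 goes with the chlorine or with where it sits stays open, as every other arm shown differs in both; a 4-chlorophenyl arm would bear on this. Also open, on these data alone, is how a 4-hydroxyphenyl or 4-carboxyphenyl arm would read.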